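The compounds below may be only part of what the source reports. "The series", "measured", "known", "first", "only" and "open" are said of these compounds alone.

Measured so far in an ADME assay on Vero cells (Chlorocebus sabaeus) for cytotoxicity, read by neutral red uptake, with a stated time of 3 days; a lower number here means that less compound is tolerated, a higher number that more compound is tolerated:
compound 1 `CC(CN(C)C)NC(=O)c1cc(C(C)C)nc2c1cnn2C(C)C`, 117000 nM;
compound 2 `CC(CN)NC(=O)c1cc(C(C)C)nc2c1cnn2C(C)C`, 135000 nM;
compound 3 `CC(C)n1ncc2c(C(=O)NCCN(C)C)cc(C(C)(C)C)nc21`, 34400 nM.

Compound 2 carries the change amino in place of dimethylamino on a saturated chain carbon, two bonds along the chain from an amide-type nitrogen against compound 1, and the step of a 1.2-fold higher number from compound 1 to compound 2 (0.06 log units; within the scatter) shows no effect beyond the scatter. Compound 3 and compound 1 hold the same atoms joined differently; the difference between the two cores is not broken down here. Compound 3 is the lowest of the three values, beyond the scatter of both others.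

Compound 4 `CC(C)n1ncc2c(C(=O)NCCN)cc(C(C)(C)C)nc21` is unmeasured. It carries the change amino in place of dimethylamino on a saturated chain carbon, two bonds along the chain from an amide-type nitrogen against compound 3, the same change at the same place as from compound 1 to compound 2. The step from compound 3 to compound 4 is expected to be a 1.2-fold higher number from compound 3 to compound 4 (0.07 log units; within the scatter), resting on the single earlier occurrence a 1.2-fold higher number from compound 1 to compound 2 (0.06 log units; within the scatter). In this assay compound 4 is estimated at 40000 nM, within 20000 nM to 80000 nM.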

Compound 4, half-maximal cytotoxic concentration: 23000 nM
Compound 4: the middle estimate sits 1.7-fold (0.24 log units) above what was measured; measured number inside the range.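

In this assay the change from dimethylamino to amino gives a 1.5-fold lower number from compound 3 to compound 4 (0.17 log units; within the scatter), which is no effect beyond the scatter. Set beside the earlier step, the change carries from one core to the other with no gap beyond the scatter: the same change on two cores in this assay, a 1.2-fold higher number (0.06 log units; within the scatter) from compound 1 to compound 2 and a 1.5-fold lower number (0.17 log units; within the scatter) from compound 3 to compound 4, 1.7-fold (0.24 log units) apart, within the scatter of two such steps. Among these compounds, this shows only that two pairs agree in showing no effect in this one assay; it gives no rule for other cores, and the opposite signs of the two steps carry no meaning.

As far as these compounds go, whether methylamino, a carboxylic acid or a longer chain in place of the amino group would move the number beyond the scatter stays open. From the compounds shown here alone, how the change behaves on a third core also stays open.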